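Stripping the 4-Methylphenyl Group from Compound 1

A few compounds are considered here, and "the series" means these few. Any claim that something is new, unique, unknown or untested is made for them only; others in the source may bear on it.

Measured so far:
compound 1: `Cc1ccc(Nc2nccc(-c3ccnc4ccccc34)n2)cc1` — 100%
compound 2: `FC(F)(F)c1ccc(Nc2nccc(-c3cnc4ccccc4c3)n2)cc1` — 24%

Of the compounds shown here, two have been tested in a functional assay on HCT-15 cells (Homo sapiens) for cytotoxicity, read by sulforhodamine B assay, with a stated time of 48 h, tested at 50 uM; a lower number here means less inhibition, a higher number more inhibition at the concentration tested (going by the name of the read-out). Compound 1 `Cc1ccc(Nc2nccc(-c3ccnc4ccccc34)n2)cc1` gives 100%, the highest of the two numbers recorded. Compound 2 `FC(F)(F)c1ccc(Nc2nccc(-c3cnc4ccccc4c3)n2)cc1` gives 24%, a gap beyond the usual scatter. These two compounds differ from each other in more than one place, so nothing beyond the two values themselves can be said about their relation.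

Compound 3 `Nc1nccc(-c2ccnc3ccccc23)n1` has not yet been measured. Compared with compound 1 it shows one change: hydrogen in place of 4-methylphenyl on a nitrogen on an aromatic ring. Among the measured compounds shown here, no pair of measured compounds separated by a single change is available, so the size of this step has to be judged from the structural change alone. A downward step from compound 1 to compound 3 of a number 65 percentage points lower from compound 1 to compound 3 (beyond the scatter) is expected, beyond the scatter, because compound 1 gives 100% and the change removes a large part of what compound 1 carries on that nitrogen. Compound 3 is therefore estimated to give 35%, within a range from 5% to 75%.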

Compound 3, a percentage reported as inhibition, at one concentration (the size of the read-out at that concentration, not a potency): "not active" (no number reported)
For compound 3 the study gives words and no number, so the estimate cannot be set against anything.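

In this assay, among the compounds shown here, compound 3 is reported as not active, with no number given, so no step from compound 1 to compound 3 can be read. Nothing measured here bears on this result. The compounds shown leave open how far for compound 1 the 100% depends on its 4-methylphenyl group.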